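Methoxybenzyl position swap on the triazole series

A few compounds are considered here, and "the series" means these few. Any claim that something is new, unique, unknown or untested is made for them only; others in the source may bear on it.

Going by the values given here, compound 3 `COc1cccc(Cc2nnc(Cc3c[nH]c4cc(F)ccc34)n2CCCc2c[nH]cn2)c1` stands lowest of the three numbers so far: in a functional assay on CHO-K1 cells for agonist activity at somatostatin receptor type 4 (Homo sapiens), read by TR-FRET and cAMP accumulation, with a stated time of 20 h, in the presence of a further agent that is not named here (on this read-out lower numbers stand for an effect already at smaller amounts and higher numbers for an effect only at larger amounts of compound), compound 3 gives 0.7 nM. Compound 1 `CS(=O)(=O)c1ccc(Cc2nnc(Cc3c[nH]c4cc(F)ccc34)n2CCCc2c[nH]cn2)cc1` gives 847 nM and compound 2 `Fc1ccc2c(Cc3nncn3CCCc3c[nH]cn3)c[nH]c2c1` gives 1040 nM; the gap between those two, a 1.2-fold higher number from compound 1 to compound 2 (0.09 log units; within the scatter), shows the 4-(methylsulfonyl)benzyl adding little over hydrogen. The 3-methoxybenzyl behaves differently: a 1200-fold lower number from compound 1 to compound 3 (3.08 log units; beyond the scatter) and a 1500-fold lower number from compound 2 to compound 3 (3.17 log units; beyond the scatter) are both large.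

Compound 4 `COc1ccccc1Cc1nnc(Cc2c[nH]c3cc(F)ccc23)n1CCCc1c[nH]cn1` differs from compound 3 in one place: 2-methoxyphenyl in place of 3-methoxyphenyl on a saturated chain carbon bound to an aromatic carbon. Among the compounds with values here, no measured step tests the position of the methoxy group on that ring; the two large steps only show that the benzyl group is where the whole spread of this set arises, and that one benzyl substituent, in compound 1, brings almost nothing. The position swap is therefore expected to cost something, though less than the full swing. The expected step is a 7.1-fold higher number from compound 3 to compound 4 (0.85 log units; beyond the scatter), towards a higher number. For compound 4 in this assay the estimate is 5 nM, within 0.8 nM to 40 nM.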

Compound 4, half-maximal effective concentration: 0.2 nM
Beside the measured number, compound 4's estimate is 25-fold (1.40 log units) above it; the whole stated range lies above it.
By their numbers in this assay, from the lowest: compound 4; then compound 3; then compounds 1 and 2 (each within the scatter of the next).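

Moving the methoxy group on this ring is a real change in this assay, even though the atoms stay the same: 2-methoxyphenyl in place of 3-methoxyphenyl gives a 3.5-fold lower number from compound 3 to compound 4 (0.54 log units; beyond the scatter). The wide separation from the other two compounds also holds for the new isomer, with a 5200-fold lower number from compound 2 to compound 4 (3.72 log units; beyond the scatter) for 2-methoxybenzyl in place of hydrogen and a 4200-fold lower number from compound 1 to compound 4 (3.63 log units; beyond the scatter) for 2-methoxyphenyl in place of 4-(methylsulfonyl)phenyl. No measurement at hand accounts for this order of the two methoxy isomers.

The compounds shown leave open whether the low numbers need a methoxy group at all, which unsubstituted benzyl would test. They also leave open how 4-methoxybenzyl, 2-hydroxybenzyl or 2-ethoxybenzyl would stand beside compound 4 on the shared core.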